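Notes on compound 3 and the step to compound 4

This account rests on a few compounds, and the source may have more. Where it says the series, first, only, none or still open, it means among the compounds named here.

Compound 3 `COc1cc(NC(C)CCCNC(=O)n2nnc3ccccc32)c2ncccc2c1` is the starting point for this step. In a functional assay on SW-620 cells (Homo sapiens), read by MTT assay, with a stated time of 72 h (a lower number here means a stronger inhibitor, a higher number a weaker inhibitor), compound 3 reaches only the limit of the assay, > 100000 nM. Compound 2 `CCN(CC)C(=O)NCCCC(C)Nc1cc(OC)cc2cccnc12` likewise gives only a limit in this assay, > 100000 nM. Two of the three measured values sit at that limit (the limit of > 100000 nM in this assay, at which 2 of the 3 values shown sit), so compound 3 cannot be ranked against compound 2. For the measured compounds named here, the only numeric value in the set belongs to compound 1 `COc1cc(NC(C)CCCNC(=O)NC2CCCCC2)c2ncccc2c1`, which in this assay gives 49000 nM. From compound 1 the measured steps are an at least 2.0-fold higher number from compound 1 to compound 3 (0.30 log units; that floor lies within the scatter) and an at least 2.0-fold higher number from compound 1 to compound 2 (0.30 log units; that floor lies within the scatter), while the step that the two limits leave unreadable from compound 2 to compound 3 remains unreadable.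

Compound 4 `COc1cc(NC(C)CCCNC(=O)NCC2CCCCC2)c2ncccc2c1` differs from compound 3 by a group of 8 heavy atoms (7 carbon, 1 nitrogen; one six-membered non-aromatic ring of carbon only) in place of a group of 9 heavy atoms (6 carbon, 3 nitrogen; one five-membered aromatic ring with 3 hetero atoms, one six-membered aromatic ring of carbon only), on a carbonyl carbon. This largely reverses the change measured as an at least 2.0-fold higher number from compound 1 to compound 3 (0.30 log units; that floor lies within the scatter), restoring a six-membered non-aromatic ring of carbon only, now within a (cyclohexylmethyl)amino group of 8 heavy atoms. Going by the values given here, that single step is the only measured evidence bearing on the change, and its floor lies within the scatter, so the recovery expected in the reverse direction is of at least that size but not firmly larger. Near the value of compound 1, compound 4 is therefore expected to give 60000 nM, with a range of 20000 nM to 200000 nM. The step from compound 3 to compound 4 that this estimate means is an at least 1.6-fold lower number from compound 3 to compound 4 (0.22 log units; that floor lies within the scatter), expected as a fall, with a fair chance that the assay again reports only a limit.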

Compound 4, half-maximal inhibitory concentration: 61000 nM
Beside the measured number, compound 4's estimate is 1.0-fold (0.01 log units) below it; the measured number falls inside the stated range.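

On a carbonyl carbon, (cyclohexylmethyl)amino gives the second numeric result in this assay, so the two compounds carrying a six-membered non-aromatic ring of carbon only, compound 1 and compound 4, are the two that return a number, whereas compound 2 and compound 3 return only limits. Replacing the group with the five-membered aromatic ring gives an at least 1.6-fold lower number from compound 3 to compound 4 (0.21 log units; that floor lies within the scatter), and replacing diethylamino gives an at least 1.6-fold lower number from compound 2 to compound 4 (0.21 log units; that floor lies within the scatter), so both steps are floors that do not by themselves clear the scatter. On the amide-type nitrogen, cyclohexylmethyl in place of cyclohexyl gives a 1.2-fold higher number from compound 1 to compound 4 (0.10 log units; within the scatter), so this change has no readable effect in the series.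

Going by these compounds, whether a phenyl ring in place of the cyclohexyl ring, or a longer chain such as cyclohexylethyl on the same nitrogen, would move the number beyond the scatter remains open. The step between compound 2 and compound 3 still cannot be read: the limit of > 100000 nM in this assay, at which 2 of the 4 values shown sit.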